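Anilino-thiazolyl Chalcones and Cytotoxicity in Lung Carcinoma Cells

The source may report more compounds than this note shows. Statements on the series, on what has been measured and on what is new or still open speak of the compounds shown alone.

Compound 1, `Cc1ccccc1Nc1nc(C)c(C(=O)/C=C/c2ccc(Cl)cc2)s1`, > 25000 nM in a functional assay on NCI-H460 cells (Homo sapiens) for cytotoxicity, read by MTT assay; on this read-out higher numbers stand for weaker inhibition and lower numbers for stronger inhibition; this is a limit of the assay, not a number.
Compound 2, `Cc1nc(Nc2ccc(Cl)c(Cl)c2)sc1C(=O)/C=C/c1ccccc1`, 22700 nM.

Compound 2 gives the only number shown, while the other value is a limit, as the limit of > 25000 nM in this assay, at which 1 of the 2 values shown sits, shows. Compound 3, `Cc1ccccc1Nc1nc(C)c(C(=O)/C=C/c2ccccc2)s1`, differs from compound 2 by 2-methylphenyl in place of 3,4-dichlorophenyl on a nitrogen on an aromatic ring. Within the data shown here, no measured step covers this change, so no step beyond the scatter is expected in this assay. Compound 3 is expected to give 28000 nM, between 12000 nM and 70000 nM, an estimated step of a 1.2-fold higher number from compound 2 to compound 3 (0.09 log units; within the scatter).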

Compound 3, half-maximal inhibitory concentration: > 25000 nM
Compound 3: only a limit was reported (the forecaster's own chance of this, stated with the estimate: 55%); the middle value is on the limit's open side.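

In this assay, 2-methylphenyl in place of 3,4-dichlorophenyl on a nitrogen on an aromatic ring gives an at least 1.1-fold higher number from compound 2 to compound 3 (0.04 log units; that floor lies within the scatter), so this change is not shown to move the read-out beyond the scatter. Compound 3 gives > 25000 nM, which is a limit and not a number. The step from compound 1 to compound 3, hydrogen in place of chloro on an aromatic carbon, cannot be read, as both values are limits. Most of the series remains unresolved on this read-out: the limit of > 25000 nM in this assay, at which 2 of the 3 values shown sit. Going by these compounds, whether an amine or a carboxylic acid on this nitrogen's aryl ring would give a lower number in this assay stays open.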